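The source may report more compounds than this note shows. Statements on the series, on what has been measured and on what is new or still open speak of the compounds shown alone.

Measured in an assay on MDA-MB-231 cells for displacement of a labelled ligand from C-X-C chemokine receptor type 4 (Homo sapiens), read by fluorescence and microscopy, with stated times of 10 min and 30 min; a higher number here means that more compound is needed for the effect, a lower number that less compound is needed: compound 1 `O=C(NCc1ccc(CNS(=O)(=O)c2ccc(Cl)cc2)cc1)c1cccnc1` gives 1000 nM; compound 2 `O=C(NCc1ccc(CNS(=O)(=O)c2cccc(F)c2)cc1)c1cccnc1` gives 1000 nM.

In this assay compound 2 stands level with compound 1 within the scatter. Compound 3 `O=C(NCc1ccc(CNS(=O)(=O)c2ccc(F)cc2)cc1)c1cccnc1` differs from compound 2 by 4-fluorophenyl in place of 3-fluorophenyl on a sulfonyl sulfur. For the measured compounds named here, the only measured step that bears on this, from compound 1 to compound 2, gave no change at the digits printed from compound 1 to compound 2 (within the scatter) when a 3-fluorophenyl replaced a 4-chlorophenyl on the sulfonyl sulfur. A second small change to the same group is therefore expected to give no change at the digits printed from compound 2 to compound 3 (within the scatter), nothing beyond the scatter. Compound 3 is estimated at 1000 nM, with a range from 500 nM to 2000 nM.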

Compound 3, effective concentration (reported as EC, without a stated level of effect): 100 nM
The estimate for compound 3 lay 10-fold (1.00 log units) above the measured number; measured number below the stated range.
By their numbers in this assay, from the lowest: compound 3; then compounds 1 and 2 (each within the scatter of the next).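

On the sulfonyl sulfur, 4-fluorophenyl in place of 3-fluorophenyl gives a 10-fold lower number from compound 2 to compound 3 (1.00 log units; beyond the scatter) in this assay even though the two groups hold the same atoms, so where the fluorine sits matters here. Fluoro in place of chloro on an aromatic carbon gives a 10-fold lower number from compound 1 to compound 3 (1.00 log units; beyond the scatter) as well, so the level values of the first two compounds did not mean that this group accepts any small change. Nothing measured here explains either step.

On these data alone, what a methyl, a methoxy or an amine would give in place of the fluoro remains open. So does whether these steps would recur on a different core.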